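A Cyanopyridine in Place of an Oxazole on the Core

A few compounds are considered here, and "the series" means these few. Any claim that something is new, unique, unknown or untested is made for them only; others in the source may bear on it.

Compound 1 `Nc1nc(-c2ncco2)nc2sc(Cc3ccccc3)cc12` is one of two compounds from this study tested in a functional assay on CHO-K1 cells for antagonist activity at adenosine receptor A1 (Homo sapiens), read by a beta-galactosidase reporter and cAMP accumulation, with stated times of 15 min and 6 h; on this read-out higher numbers stand for weaker inhibition and lower numbers for stronger inhibition. In this assay compound 1 gives 310 nM. Going by the values given here, that is the only plain number available. The second compound, compound 2 `N#Cc1cccc(-c2nc(N)c3cc(Cc4ccccc4F)sc3n2)c1`, is reported only as a limit. For compound 2 this assay returns < 16 nM, which is a limit of the assay and not a number. So one of the two values sits at the limit of < 16 nM in this assay, at which 1 of the 2 values shown sits, and compound 1 stands alone as the sole measured point.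

Compound 3 `N#Cc1cncc(-c2nc(N)c3cc(Cc4ccccc4)sc3n2)c1` has not yet been measured. It differs from compound 1 in a single place: 5-cyanopyridin-3-yl in place of 1,3-oxazol-2-yl on an aromatic carbon. Among the compounds with values here, no step between two measured compounds is available to guide this change, so the expectation rests on compound 1 alone. For compound 3 the step of an 8.9-fold lower number from compound 1 to compound 3 (0.95 log units; beyond the scatter) is expected to run toward stronger inhibition, beyond the usual scatter. Compound 3 is therefore estimated at about 35 nM, with a likely range from 8 nM to 150 nM.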

Compound 3, inhibition constant: 1160 nM
The estimate for compound 3 lay 33-fold (1.52 log units) below the measured number; measured number outside the range, above it.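

In this assay, going by these compounds alone, the exchange gives a 3.7-fold higher number from compound 1 to compound 3 (0.57 log units; beyond the scatter) and so runs toward weaker inhibition, the first direct reading of a change at this aromatic carbon of the shared core, which lies between two ring nitrogen atoms. Until now compound 1 stood alone as a single number, whereas this pair shows that the position responds to what is placed on it and that a six-membered aromatic ring bearing a nitrile does not improve on the five-membered 1,3-oxazol-2-yl in this series. Within the data shown here, compound 2 gives < 16 nM as a limit of the assay and not a number, and it differs from compound 3 in more than one place, so it offers no step to set beside this one.

The compounds shown leave open how a quite different group on this carbon, such as an amine or a carboxylic acid, would compare with 1,3-oxazol-2-yl, and whether the ring or its nitrile accounts for the change. Nothing among the evidence available bears on why the number rose with this exchange.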